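Swapping the benzyl halogen in a cytotoxicity series

A few compounds are considered here, and "the series" means these few. Any claim that something is new, unique, unknown or untested is made for them only; others in the source may bear on it.

Within the data shown here, compound 2 `COc1cc2c(c(OCc3ccc(Cl)cc3)c1OC)C(=O)[C@]1(OC)C=C[C@H]2N(C(=O)OCC(C)C)N1C(=O)OCC(C)C` is one of two compounds measured in an ADME assay on KB cells (Homo sapiens) for cytotoxicity; on this read-out lower numbers stand for an effect already at smaller amounts and higher numbers for an effect only at larger amounts of compound. Compound 2 gives 42 ug/mL, and compound 1 `CCCCOc1c(OC)c(OC)cc2c1C(=O)[C@]1(OC)C=C[C@H]2N(C(=O)OCC(C)C)N1C(=O)OCC(C)C` gives 22.1 ug/mL; the two numbers lie within the scatter of each other, so neither can be set apart from the other, and compound 2 is simply one of a pair that behave alike.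

Compound 3 `COc1cc2c(c(OCc3ccccc3F)c1OC)C(=O)[C@]1(OC)C=C[C@H]2N(C(=O)OCC(C)C)N1C(=O)OCC(C)C` differs from compound 2 in one place: 2-fluorophenyl in place of 4-chlorophenyl on a saturated chain carbon bound to an oxygen on an aromatic ring. Among the measured compounds shown here, the only measured step that bears on this spot is a 1.9-fold higher number from compound 1 to compound 2 (0.28 log units; within the scatter), a change of the group on the same saturated chain carbon that did not move the number beyond the scatter. For the measured compounds named here, with that as the sole guide, no step beyond the scatter is expected for compound 3 in this assay, and the step is estimated as a 1.3-fold lower number from compound 2 to compound 3 (0.12 log units; within the scatter). Compound 3 is therefore expected to give about 32 ug/mL, with a range from 13 ug/mL to 80 ug/mL.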

Compound 3, concentration for half-maximal effect: 109 ug/mL
Compound 3: middle estimate off by 3.4-fold (0.53 log units), on the low side; measured number above the stated range.
By their numbers in this assay, from the lowest: compounds 1 and 2 (each within the scatter of the next); then compound 3.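

In this assay, the group on a saturated chain carbon bound to an oxygen on an aromatic ring can move the number beyond the scatter: 2-fluorophenyl in place of 4-chlorophenyl gives a 2.6-fold higher number from compound 2 to compound 3 (0.41 log units; beyond the scatter), and 2-fluorophenyl in place of propyl gives a 4.9-fold higher number from compound 1 to compound 3 (0.69 log units; beyond the scatter). The earlier pair had shown only a step within the scatter, whereas this change separates two groups with the same count of heavy atoms, each a single aromatic ring of carbon carrying one halogen. No measurement on these compounds says why the number rises.

The step changes the halogen and its place on the ring together, and the compounds shown cannot separate the two. On these data alone, how 2-chlorophenyl, 4-fluorophenyl or a chain ending in an amine would read at this position remains open.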